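Tert-butyl to neopentyl on a hydroxyacyl prolinamide thrombin series

The source may report more compounds than this note shows. Statements on the series, on what has been measured and on what is new or still open speak of the compounds shown alone.

Measured compounds:
- compound 1, `CC(C)(C)[C@@H](O)C(=O)N1[C@@H]2C[C@@H]2C[C@H]1C(=O)NCc1cc(Cl)ccc1-n1cnnn1`: 1100 nM
- compound 2, `CC(C)(C)[C@@H](O)C(=O)N1CSC[C@H]1C(=O)NCc1cc(Cl)ccc1-n1cnnn1`: 1200 nM

In a functional assay on a cell-free system (plasma, Homo sapiens), with a stated time of 3 min (on this read-out higher numbers stand for weaker inhibition and lower numbers for stronger inhibition), compound 1 gives 1100 nM. Compound 2 gives 1200 nM in this assay, and the two numbers lie within the scatter of each other, so neither compound can be called stronger than the other on this evidence. Compound 1 carries the lowest of the two numbers, with compound 2 as its nearest neighbour.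

The unmeasured compound 3, `CC(C)(C)C[C@@H](O)C(=O)N1[C@@H]2C[C@@H]2C[C@H]1C(=O)NCc1cc(Cl)ccc1-n1cnnn1`, differs from compound 1 in one place: neopentyl in place of tert-butyl on a saturated chain carbon bound to a carbonyl carbon and an oxygen on a saturated carbon.

For the measured compounds named here, no pair of measured compounds differing in this one place has been recorded, so the size of this step in this assay cannot be read from the numbers at hand. In the absence of such a comparison, compound 3 is expected to stay close to compound 1, with a step from compound 1 to compound 3 of about a 1.2-fold higher number from compound 1 to compound 3 (0.07 log units; within the scatter), not clearly beyond the scatter in either direction. Compound 3 is therefore estimated at 1300 nM, within a range of 400 nM to 4500 nM.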

Compound 3, half-maximal inhibitory concentration: 520 nM
The estimate for compound 3 lay 2.5-fold (0.40 log units) above the measured number, within the range that was stated.
By their numbers in this assay, from the lowest: compound 3; then compounds 1 and 2 (each within the scatter of the next).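

In this assay, neopentyl in place of tert-butyl on a saturated chain carbon bound to a carbonyl carbon and an oxygen on a saturated carbon gives a 2.1-fold lower number from compound 1 to compound 3 (0.33 log units; beyond the scatter), a modest gain in inhibition. The earlier compounds shown here both carried tert-butyl here, so they showed nothing about this position; it now emerges that the number responds to the group placed there, and that the larger neopentyl is tolerated with stronger inhibition. Nothing measured here accounts for this step.

From the compounds shown here alone, whether the same change would give a similar step on the core of compound 2 remains open. So does whether a longer chain, a cyclohexyl ring or an amine at this place would lower the number further or reverse the gain.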